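The source may hold more compounds than are shown below. What is called first, only, known or untested is meant among the compounds shown, and "the series" means these compounds.

Three compounds that share a fused two-ring unit carrying a halogen have been tested in a functional assay on cells (Leukemia cell, Homo sapiens) for cytotoxicity, read by sulforhodamine B assay, with a stated time of 48 h (a higher number here means a weaker inhibitor of growth, a lower number a stronger inhibitor of growth), and a fourth awaits measurement. Compound 1 `COc1ccc(C2=NN(C3=NC(=O)/C(=C4\C(=O)Nc5ccc(Br)cc54)S3)C(c3ccc(Cl)cc3)C2)cc1` carries bromo on that ring and gives 14000 nM. Compound 2 `COc1ccc(C2=NN(C3=NC(=O)/C(=C4\C(=O)Nc5ccc(Cl)cc54)S3)C(c3ccc(Cl)cc3)C2)cc1` differs from it in one place, (chloro in place of bromo on an aromatic carbon), and this step gave a 16-fold lower number from compound 1 to compound 2 (1.20 log units; beyond the scatter). In this assay compound 2 gives 890 nM. Compound 3 `CN(C)c1ccc(C2CC(c3ccccc3)=NN2C2=NC(=O)/C(=C3\C(=O)Nc4ccc(Br)cc43)S2)cc1` keeps the halogen-bearing ring of compound 1 but the rest of the molecule is different; the difference between the two cores is not broken down here. In this assay compound 3 gives 1290 nM, a number that sits within the scatter of the value of compound 2 and far from that of compound 1.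

Compound 4 `CN(C)c1ccc(C2CC(c3ccccc3)=NN2C2=NC(=O)/C(=C3\C(=O)Nc4ccc(Cl)cc43)S2)cc1` arises from compound 3 by the same change that took compound 1 to compound 2: chloro in place of bromo on an aromatic carbon. The place is the same in both pairs, on an aromatic carbon of a six-membered aromatic ring of carbon only, part of a fused or bridged system of two rings, meta to a fused ring and para to a fused ring. Among the measured compounds shown here, only one measured example of this swap exists, and it was made on a different core, so its size need not carry over unchanged. For the measured compounds named here, for compound 4 the expected step is a 5.2-fold lower number from compound 3 to compound 4 (0.71 log units; beyond the scatter), set smaller than the measured one because the only guide is a 16-fold lower number from compound 1 to compound 2 (1.20 log units; beyond the scatter) on another core. Compound 4 is therefore estimated at 250 nM, with a likely range from 60 nM to 1300 nM.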

Compound 4, concentration for total growth inhibition: 3110 nM
Estimate against measurement, compound 4: 12-fold (1.09 log units) below; the measured number lies above the stated range.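

Putting chloro in place of bromo on compound 3 gave, in this assay, a 2.4-fold higher number from compound 3 to compound 4 (0.38 log units; beyond the scatter), so on this core the swap moved the number the opposite way from the large drop seen on the core of compound 1. Set side by side, the two results differ in direction as well as in size, and the gap between them is larger than repeat measurements would explain: the same change on two cores in this assay, a 16-fold lower number (1.20 log units; beyond the scatter) from compound 1 to compound 2 and a 2.4-fold higher number (0.38 log units; beyond the scatter) from compound 3 to compound 4, 38-fold (1.58 log units) apart, beyond the scatter of two such steps This shows that the effect of this swap, at this place on the ring, cannot simply be carried from one core to the other in this series, although it rests on only two pairs of compounds and does not show which part of the cores is responsible, as they differ in more than one place, or why the swap acts as it does.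

From the compounds shown here alone, whether fluoro or a methyl group at the same place would behave alike on both cores remains open. Among the compounds shown here, also open is whether a core that differs from compound 1 in only one place would follow compound 1 and compound 2 or instead compound 3 and compound 4.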